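Trading trifluoromethyl for methyl: a clearance estimate

The compounds below may be only part of what the source reports. "The series", "measured", "known", "first", "only" and "open" are said of these compounds alone.

In an in vitro ADME assay on microsomes from Gut (Homo sapiens) for metabolic stability, in the presence of a further agent that is not named here (on this read-out lower numbers stand for slow clearance and higher numbers for fast clearance), compound 1 `COc1ccc(C)cc1Cn1c(C(=O)NCC(C)(C)CO)cc2cc(C#N)ccc21` gives 64 mL.min-1.g-1 and compound 2 `Cc1ccc(C(F)(F)F)cc1Cn1c(C(=O)NCC(C)(C)CO)cc2cc(C#N)ccc21` gives 102 mL.min-1.g-1 on the same scale. Going by the values given here, these two values lie within the usual scatter of repeated measurements, so compound 2 cannot be told apart from compound 1, the only other compound measured. Compound 3 `Cc1ccc(C)c(Cn2c(C(=O)NCC(C)(C)CO)cc3cc(C#N)ccc32)c1` has not been measured yet. It differs from compound 2 at one place, with methyl in place of trifluoromethyl on an aromatic carbon and the rest unchanged. Among the compounds with values here, no measured pair shows this swap alone, so the only guide is the narrow span between compound 1 at 64 mL.min-1.g-1 and compound 2 at 102 mL.min-1.g-1 so far. The expected change is a 1.3-fold lower number from compound 2 to compound 3 (0.11 log units; within the scatter) and it stays inside the usual scatter, so no real shift in either direction is foreseen. The estimate for compound 3 is 80 mL.min-1.g-1 (expected range 45 mL.min-1.g-1 to 150 mL.min-1.g-1).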

Compound 3, intrinsic clearance in microsomes: 124 mL.min-1.g-1
The estimate for compound 3 lay 1.6-fold (0.19 log units) below the measured number, and the stated range covers the measured number.
By their numbers in this assay, from the lowest: compounds 1, 2 and 3 (each within the scatter of the next).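

In this assay, going by these compounds alone, the step of a 1.2-fold higher number from compound 2 to compound 3 (0.08 log units; within the scatter) gives the first direct reading of methyl in place of trifluoromethyl on an aromatic carbon, para to a methyl group, and it stays within the scatter. Thus, despite the loss of the three fluorine atoms, this swap produces no measurable shift in clearance here, and the step of a 1.9-fold higher number from compound 1 to compound 3 (0.29 log units; within the scatter) for methyl in place of methoxy at a different aromatic carbon also stays within the scatter. No supporting measurement explains why either swap leaves the read-out unresolved.

From the compounds shown here alone, these compounds test only a few small groups, so it remains open whether an amine, a carboxylic acid or a longer chain at the trifluoromethyl position would produce a real shift. A single pair also cannot show whether the same swap would behave alike on a different core.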